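Quinolone amide series: aryl swap on the ring nitrogen

This account rests on a few compounds, and the source may have more. Where it says the series, first, only, none or still open, it means among the compounds named here.

Going by the values given here, compound 2 (`O=C(Nc1ccc(Oc2ccnc3[nH]ccc23)c(F)c1)c1cn(-c2ccc(Br)cc2)c2ccccc2c1=O`) is the one member of this set with a reported number: in a functional assay on HepG2 cells (Homo sapiens) for inhibition, read by MTT assay, with a stated time of 72 h (a lower number here means a stronger inhibitor, a higher number a weaker inhibitor), compound 2 gives 710 nM. Compound 1 (`O=C(Nc1ccc(Oc2ccnc3[nH]ccc23)cc1)c1cn(-c2ccc(C(F)(F)F)cc2Cl)c2ccccc2c1=O`) belongs to the same series, but in this assay compound 1 is recorded as "not determined" (no result reported), so compound 2 stands alone on the numbers shown and no step between measured compounds can be drawn from these data.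

Compound 3 (`O=C(Nc1ccc(Oc2ccnc3[nH]ccc23)c(F)c1)c1cn(-c2ccc(C(F)(F)F)cc2Cl)c2ccccc2c1=O`) differs from compound 2 in one place: 2-chloro-4-(trifluoromethyl)phenyl in place of 4-bromophenyl on an aromatic nitrogen. Among the compounds with values here, with no measured pair available to calibrate this change, the size of the step is open. The step in this assay from compound 2 to compound 3 is expected to be a 1.4-fold lower number from compound 2 to compound 3 (0.15 log units; within the scatter), a shift that is expected to fall within the usual scatter, with no clear direction supported by the data shown. The estimate for compound 3 in this assay is 500 nM, with an expected range from 150 nM to 1800 nM. Within the data shown here, a result outside that band would be the first real information on this aryl change.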

Compound 3, half-maximal inhibitory concentration: 1840 nM
Compound 3: the middle estimate sits 3.7-fold (0.57 log units) below what was measured; measured number above the stated range.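

In this assay the aryl group on the aromatic nitrogen is not a neutral site, since 2-chloro-4-(trifluoromethyl)phenyl in place of 4-bromophenyl gives a 2.6-fold higher number from compound 2 to compound 3 (0.41 log units; beyond the scatter) and so moves the result beyond the scatter, toward a weaker inhibitor. The step is modest, and it is a single comparison on one shared core, so it shows that this position responds to this change but sets no trend for the series. No data shown here bear on why compound 3 reads weaker than compound 2.

Steps involving compound 1 cannot be read, and the one readable step swaps bromine for chlorine and trifluoromethyl together, so the contribution of each group stays unseparated. Also open, going by these compounds, is how this nitrogen would respond to a phenyl carrying chlorine alone or trifluoromethyl alone, or to a different kind of substituent, such as an amine or a carboxylic acid on the aryl ring, or a longer alkyl chain in place of the aryl group.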